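Swapping Naphthyl for Chlorophenoxy: Expected Cell Toxicity

The source may hold more compounds than are shown below. What is called first, only, known or untested is meant among the compounds shown, and "the series" means these compounds.

Measured compounds in an ADME assay on HepG2 cells (Homo sapiens) for cytotoxicity, read by luminescence, CellTiter-Glo and ATP content, with a stated time of 72 h; on this read-out lower numbers stand for an effect already at smaller amounts and higher numbers for an effect only at larger amounts of compound:
- compound 1, `Clc1ccc(Oc2ccc3c(NCCCNCc4ccco4)ccnc3c2)cc1`, gives 7800 nM
- compound 2, `c1coc(CNCCCNc2ccnc3cc(-c4cccc5ccccc45)ccc23)c1`, gives 5600 nM
- compound 3, `COc1cccc(CNCCCNc2ccnc3cc(-c4cccc5ccccc45)ccc23)c1O`, gives 2520 nM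

Compound 4, `COc1cccc(CNCCCNc2ccnc3cc(Oc4ccc(Cl)cc4)ccc23)c1O`, has not yet been measured in this assay. It differs from compound 3 in one place: 4-chlorophenoxy in place of naphthalen-1-yl on an aromatic carbon. The same change has already been made once among the measured compounds, from compound 2 to compound 1: 4-chlorophenoxy in place of naphthalen-1-yl on an aromatic carbon. That step gave a 1.4-fold higher number from compound 2 to compound 1 (0.14 log units; within the scatter), so on this read-out the exchange barely moved the number.

The two starting points, compound 2 and compound 3, differ elsewhere on the molecule: 2-hydroxy-3-methoxyphenyl in place of furan-2-yl on a saturated chain carbon bound to an amine nitrogen. That difference gave a 2.2-fold lower number from compound 2 to compound 3 (0.35 log units; beyond the scatter), a modest shift, and it leaves compound 3 with the lowest number of the three measured compounds, beyond the scatter from both others.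

Because a 1.4-fold higher number from compound 2 to compound 1 (0.14 log units; within the scatter) came from the same exchange at the same place on the core, the step from compound 3 to compound 4 is expected to resemble it, that is, a 1.4-fold higher number from compound 3 to compound 4 (0.14 log units; within the scatter). Whether the different group on the amine side of compound 3 alters the outcome cannot be judged from a single earlier example. Compound 4 is therefore expected to give about 3500 nM in this assay, likely between 1500 nM and 8500 nM.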

Compound 4, half-maximal effective concentration: 5700 nM
Compound 4: middle estimate off by 1.6-fold (0.21 log units), on the low side, within the range that was stated.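

In this assay, putting 4-chlorophenoxy in place of naphthalen-1-yl gave a 2.3-fold higher number from compound 3 to compound 4 (0.35 log units; beyond the scatter), and this can be set beside the same exchange on the core that carries furan-2-yl: the same change on two cores in this assay, a 1.4-fold higher number (0.14 log units; within the scatter) from compound 2 to compound 1 and a 2.3-fold higher number (0.35 log units; beyond the scatter) from compound 3 to compound 4, 1.6-fold (0.21 log units) apart, within the scatter of two such steps. The exchange on the amine side, 2-hydroxy-3-methoxyphenyl in place of furan-2-yl, gave a 1.4-fold lower number from compound 1 to compound 4 (0.14 log units; within the scatter), and it too has an earlier counterpart: the same change on two cores in this assay, a 2.2-fold lower number (0.35 log units; beyond the scatter) from compound 2 to compound 3 and a 1.4-fold lower number (0.14 log units; within the scatter) from compound 1 to compound 4, 1.6-fold (0.21 log units) apart, within the scatter of two such steps. Each change therefore carried over from one core to the other as far as these numbers can tell, even though one step of each pair lies beyond the scatter and the other within it; this rests on just four compounds, so it shows neither that the changes would carry over to other cores nor why the numbers fall as they do.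

The compounds shown leave open whether the exchange of naphthalen-1-yl for 4-chlorophenoxy would behave alike with a plain phenyl or a pyridine ring on the amine side, or with a longer chain joining the two amine nitrogens. As far as these compounds go, whether a morpholine or a 4-fluorophenoxy group on that same aromatic carbon would give a similar number also remains open.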